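This account rests on a few compounds, and the source may have more. Where it says the series, first, only, none or still open, it means among the compounds named here.

Of the compounds shown here, two have been measured in an assay on isolated protein for inhibition of NADPH oxidase 4 (Homo sapiens), read by chemiluminescence, in the presence of a further agent that is not named here; on this read-out higher numbers stand for weaker inhibition and lower numbers for stronger inhibition. Compound 1 `CN1C(=S)N(c2ccccc2)C(=O)/C1=C\c1ccc(N(C)CCCO)cc1` gives 3390 nM, and compound 2 `CN1C(=S)N(C2CCCCC2)C(=O)/C1=C\c1ccc(N(C)CCCO)cc1O` gives 2500 nM. Compound 2 has the lower of the two numbers, but compound 1 stands close to it, within the usual scatter, so no order between them can be claimed.

Compound 3 `CN1C(=S)N(c2ccccc2)C(=O)/C1=C\c1ccc(N(C)CCCO)cc1O` has not been measured. It is derived from compound 2 by the change (phenyl in place of cyclohexyl on an amide-type nitrogen in a ring), that is, phenyl in place of cyclohexyl on an amide-type nitrogen in a ring. Compound 1 already carries a phenyl on that amide-type nitrogen, and its number in this assay sits close to that of compound 2, which gives no hint that this exchange moves the read-out far. For the measured compounds named here, no step between measured compounds isolates this change, so the expectation for compound 3 rests on that closeness alone.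

Compound 3 is therefore expected to show a step of a 1.2-fold higher number from compound 2 to compound 3 (0.08 log units; within the scatter), none beyond the scatter, in either direction. Compound 3 is estimated at 3000 nM in this assay, with a range from 1200 nM to 8000 nM.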

Compound 3, half-maximal inhibitory concentration: 5020 nM
The estimate for compound 3 lay 1.7-fold (0.22 log units) below the measured number, within the range that was stated.
By their numbers in this assay, from the lowest: compounds 2, 1 and 3 (each within the scatter of the next).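

Taken on its own for the first time in this assay, the exchange of cyclohexyl for phenyl on the amide-type nitrogen in a ring gives a 2.0-fold higher number from compound 2 to compound 3 (0.30 log units; within the scatter), so the compounds shown draw no readable distinction between the non-aromatic and the aromatic six-membered ring at this position. For the compounds shown here, the same compound 3 also yields the first reading of the hydroxy group, where hydroxy in place of hydrogen on an aromatic carbon, with the phenyl kept, gives a 1.5-fold higher number from compound 1 to compound 3 (0.17 log units; within the scatter), and this exchange likewise cannot be told apart from repeat measurement. Nothing available explains either of these small steps.

With only six-membered rings of carbon on the amide-type nitrogen among these compounds, it remains open whether a longer chain, an amine or a carboxylic acid at that position would shift the read-out beyond the scatter. The hydroxy exchange is also read with phenyl alone, so whether it behaves in the same way with cyclohexyl on that nitrogen stays unanswered.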